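From compound 2 to its phenyl analogue compound 4

A few compounds are considered here, and "the series" means these few. Any claim that something is new, unique, unknown or untested is made for them only; others in the source may bear on it.

Measured in a functional assay on MCF7 cells (Homo sapiens) for antiproliferative activity, read by MTT assay, with a stated time of 48 h; on this read-out lower numbers stand for stronger inhibition and higher numbers for weaker inhibition:
Compound 1 `COc1ccc(C2=N/C(=C\c3cc(Br)cc(Br)c3OC(C)=O)C(=O)NN2C(N)=S)cc1OC`: 13400 nM
Compound 2 `COc1cc(C2=N/C(=C\c3cc(Br)cc(Br)c3OC(C)=O)C(=O)NN2C(N)=S)cc(OC)c1OC`: 360 nM
Compound 3 `COc1cc(C2=N/C(=C\c3cc(Br)cc(Br)c3OC(C)=O)C(=O)n3c(C)nc(=S)n32)cc(OC)c1OC`: 3070 nM

Of these three, compound 2 holds the lowest number, and both others lie beyond the scatter from it. Compound 4 `COc1cc(C2=N/C(=C\c3cc(Br)cc(Br)c3OC(C)=O)C(=O)NN2c2ccccc2)cc(OC)c1OC` departs from compound 2 by a group of 6 heavy atoms (6 carbon; one six-membered aromatic ring of carbon only) in place of a group of 3 heavy atoms (1 carbon, 1 nitrogen, 1 sulfur; no ring), on an amine nitrogen in a ring, with phenyl placed on an amine nitrogen in a ring. Among the measured compounds shown here, no measured step covers this change. For the measured compounds named here, the only step available, a 37-fold lower number from compound 1 to compound 2 (1.57 log units; beyond the scatter), concerns methoxy in place of hydrogen on an aromatic carbon, so it bears only indirectly: it shows that a single change in this small set can move the number a long way. Compound 3, at 3070 nM, also stands above compound 2. Since compound 2 sits lowest, a rise in this assay seems more likely than a fall, though the data cannot settle this. The expected change is a 5.0-fold higher number from compound 2 to compound 4 (0.70 log units; beyond the scatter), a sizeable step toward weaker inhibition. For compound 4 the estimated value is 1800 nM, with an expected range of 350 nM to 9000 nM.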

Compound 4, half-maximal inhibitory concentration: 350 nM
Compound 4: middle estimate off by 5.1-fold (0.71 log units), on the high side, and the stated range covers the measured number.
By their numbers in this assay, from the lowest: compounds 4 and 2 (each within the scatter of the next); then compound 3; then compound 1.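

In this assay, the step on the amine nitrogen in a ring is a 1.0-fold lower number from compound 2 to compound 4 (0.01 log units; within the scatter), so phenyl and the group of 3 heavy atoms it replaces read alike on this core. The earlier compounds shown here showed only that a single methoxy elsewhere in the structure could carry a large step; this position accepts a six-membered aromatic ring of carbon only, and compound 4 holds a value within the scatter of compound 2 with neither the hydrogen-bond donor nor the hydrogen-bond acceptor of the group that left. Nothing at hand explains why the two groups read alike. As far as these compounds go, it remains open whether a smaller group such as methyl, or a chain ending in an amine, would read the same on this nitrogen. Also open, from the compounds shown here alone, is whether phenyl would match the group it replaced on the core of compound 1, which carries one methoxy fewer.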